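Sulfonylamide triazines: neopentyl loss on the amine nitrogen

A few compounds are considered here, and "the series" means these few. Any claim that something is new, unique, unknown or untested is made for them only; others in the source may bear on it.

Two members of the series have been run so far. Compound 1 `CCCCCNc1nc(Nc2ccc([N+](=O)[O-])cc2)nc(OCC(F)(F)F)n1` gives 35% in an ADME assay on microsomes from liver (Rattus norvegicus) for metabolic stability, with a stated time of 10 min; on this read-out lower numbers stand for a less stable compound and higher numbers for a more stable compound. Compound 2 `CC(C)(C)CNCCS(=O)(=O)NC(=O)c1ccc(Nc2nc(NC3(c4ccc(Cl)cc4)CC3)nc(OCC(F)(F)F)n2)cc1` gives 90% in this assay, the highest of the two numbers, with compound 1 lower by a gap well beyond the scatter. Compound 3 `NCCS(=O)(=O)NC(=O)c1ccc(Nc2nc(NC3(c4ccc(Cl)cc4)CC3)nc(OCC(F)(F)F)n2)cc1` is not yet measured; it differs from compound 2 by hydrogen in place of neopentyl on an amine nitrogen. Going by the values given here, no measured pair shows this change, so the expected step of a number 2 percentage points lower from compound 2 to compound 3 (within the scatter) is none beyond the scatter. Compound 3 is therefore estimated at 88%, between 70% and 98%.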

Compound 3, percent of the compound remaining: 100%
Compound 3: the middle estimate sits 12 percentage points below what was measured; measured number outside the range, above it.
By their numbers in this assay, from the lowest: compound 1; then compounds 2 and 3 (each within the scatter of the next).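

In this assay, going by these compounds alone, hydrogen in place of neopentyl on an amine nitrogen gives a number 10 percentage points higher from compound 2 to compound 3 (within the scatter) and this is the first reading of this change. At this position, 2-(neopentylamino)ethyl and 2-aminoethyl therefore cannot be told apart on this read-out, so for this pair the neopentyl group is not needed to keep the number high. No evidence at hand explains this result.

Still open, as far as these compounds go, is how a methyl group, a longer chain or an acetyl group on this amine nitrogen would read. Also open, from the compounds shown here alone, is whether the same change reads alike on a core other than that of compound 2.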